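Dropping a methyl from the core of compound 2

This account rests on a few compounds, and the source may have more. Where it says the series, first, only, none or still open, it means among the compounds named here.

Compound 1 `Cc1cccc(-c2cc(O)c3cc(C)cnc3n2)c1`: < 10 nM
Compound 2 `Cc1cc(C)c2c(O)cc(-c3ccc4ccccc4c3)nc2n1`: 3240 nM
Compound 3 `Cc1cccc(-c2cc(O)c3c(C)cc(C)nc3n2)c1`: 20900 nM

Of the compounds shown here, three share one core and have been tested in a functional assay on MDA-N cells (Homo sapiens) for antiproliferative activity; a lower number here means a stronger inhibitor of growth, a higher number a weaker inhibitor of growth. Compound 1, which carries a methyl on one ring of the core and a tolyl group, gives a value that is a limit of the assay and not a number: < 10 nM, that is the limit of < 10 nM in this assay, at which 1 of the 3 values shown sits. Among the two real numbers, compound 2 stands lowest with 3240 nM, and the nearest number is that of compound 3 at 20900 nM, a gap beyond the usual scatter. Compound 3 carries two methyls on the core together with a tolyl group, while compound 2 carries two methyls on the core together with a naphthyl group.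

Compound 4 `Cc1ccnc2nc(-c3ccc4ccccc4c3)cc(O)c12` is not yet measured. It differs from compound 2 in one place: hydrogen in place of methyl on an aromatic carbon. Going by the values given here, no measured pair shows this change on its own, so its effect is open. Compound 1, with a single methyl on the core, sits at the limit, whereas compound 3, with two methyls, is the weakest number; this points, weakly, toward a lower number for compound 4. The step from compound 2 is therefore expected to be a 3.6-fold lower number from compound 2 to compound 4 (0.56 log units; beyond the scatter), modest in size. Compound 4 is estimated at 900 nM, within 150 nM to 4500 nM.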

Compound 4, concentration for 50% growth inhibition: 204 nM
Estimate against measurement, compound 4: 4.4-fold (0.64 log units) above; the range from low to high includes it.
By their numbers in this assay, from the lowest: compound 4; then compound 2; then compound 3. At a limit, below all of these: compound 1.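

Going by these compounds alone, replacing the methyl next to the ring nitrogen with hydrogen gives a 16-fold lower number from compound 2 to compound 4 (1.20 log units; beyond the scatter) in this assay, and this is the first pair in which the change stands alone, which shows that this position matters strongly for the number when the naphthyl group is in place. Compound 4 keeps the other methyl on that ring, so the large step belongs to the one methyl that leaves and not to methyl substitution on this ring as a whole. Compound 1 alone remains a limit of the assay and not a number: the limit of < 10 nM in this assay, at which 1 of the 4 values shown sits.

Whether the same change gives a step of similar size with the tolyl group stays open, as compound 3 has no partner shown that differs from it only at this position. The compounds shown also give no cause for the step, and they do not tell how this position would respond to anything other than methyl or hydrogen, such as an ethyl group, a methoxy group or an amine.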